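A few compounds are considered here, and "the series" means these few. Any claim that something is new, unique, unknown or untested is made for them only; others in the source may bear on it.

Compound 1 `COCCNS(=O)(=O)c1ccc(C)c(C#Cc2cc(Cl)ccc2OCC(=O)O)c1`: "not determined" (no result reported)
Compound 2 `CS(=O)(=O)c1ccc(Cl)c(C#Cc2cc(Cl)ccc2OCC(=O)O)c1`: 0.025

Within the data shown here, in an ADME assay on a cell-free system (plasma, Mus musculus) (on this read-out lower numbers stand for a smaller free fraction and higher numbers for a larger free fraction), compound 2 gives 0.025, the only number so far, so it cannot be ranked. Compound 3 `Cc1ccc(S(C)(=O)=O)cc1C#Cc1cc(Cl)ccc1OCC(=O)O` differs from compound 2 by methyl in place of chloro on an aromatic carbon, with methyl in place of chloro on an aromatic carbon, para to a methylsulfonyl group. Among the measured compounds shown here, no measured pair shows this exchange, so the expectation rests on compound 2 alone. The expected change is a 1.2-fold higher number from compound 2 to compound 3 (0.08 log units; within the scatter), slightly upward and within the usual scatter in this assay. The estimated value for compound 3 is 0.03, with an expected range of 0.014 to 0.065.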

Compound 3, unbound fraction: 0.027
Beside the measured number, compound 3's estimate is 1.1-fold (0.05 log units) above it; low and high end bracket the measured number.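

In this assay, methyl in place of chloro on an aromatic carbon, para to a methylsulfonyl group, gives a 1.1-fold higher number from compound 2 to compound 3 (0.03 log units; within the scatter) and thus does not separate the two groups at this position on this read-out. Among these compounds, this is the first measured step, and it rests on one pair only. Nothing measured here offers an explanation for the result.

On these data alone, whether an amine or a longer chain on this aromatic carbon would also stay within the scatter remains open. So does whether the same exchange reads alike when a group other than methylsulfonyl sits on the ring.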